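Hydroxymethyl in place of formyl on the unsaturated chain

The compounds below may be only part of what the source reports. "The series", "measured", "known", "first", "only" and "open" are said of these compounds alone.

Measured compounds:
compound 1 `Cc1cn([C@H]2C[C@H](O)[C@@H](CO)O2)c(=O)n(/C=C/C=O)c1=O` gives 20000 nM in a functional assay on HeLa cells (Homo sapiens) for inhibition; on this read-out higher numbers stand for weaker inhibition and lower numbers for stronger inhibition
compound 2 `Cc1cn([C@@H]2O[C@H](CO)[C@@H](O)[C@H]2O)c(=O)n(/C=C/C=O)c1=O` gives 100000 nM in this assay

Compound 1 has the lowest of the two numbers in this assay; its nearest neighbour is compound 2, reached by a 5.0-fold higher number from compound 1 to compound 2 (0.70 log units; beyond the scatter), a change that sits on the saturated ring and not on the unsaturated chain.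

Compound 3 `Cc1cn([C@H]2C[C@H](O)[C@@H](CO)O2)c(=O)n(/C=C/CO)c1=O` has not yet been tested in this assay. It differs from compound 1 in one place:

hydroxymethyl in place of formyl on a double-bonded chain carbon bound to a double-bonded chain carbon

Among the compounds with values here, no measured step touches this chain: the only measured step, a 5.0-fold higher number from compound 1 to compound 2 (0.70 log units; beyond the scatter), concerns a hydroxy on a saturated ring carbon and says nothing about exchanging formyl for hydroxymethyl. The expectation for compound 3 therefore rests on compound 1 alone and carries a wide range. Compound 3 is estimated at 60000 nM in this assay, between 15000 nM and 300000 nM, which corresponds to an expected 3.0-fold higher number from compound 1 to compound 3 (0.48 log units; beyond the scatter); a weaker number than compound 1 is thought somewhat more likely than a stronger one.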

Compound 3, half-maximal inhibitory concentration: 5000 nM
Estimate against measurement, compound 3: 12-fold (1.08 log units) above; the whole stated range lies above it.
By their numbers in this assay, from the lowest: compound 3; then compound 1; then compound 2.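

Exchanging formyl for hydroxymethyl on a double-bonded chain carbon bound to a double-bonded chain carbon gives, in this assay, a 4.0-fold lower number from compound 1 to compound 3 (0.60 log units; beyond the scatter), so in this pair the formyl is not needed for the inhibition read here, and its replacement goes with the stronger inhibition. Within the data shown here, the earlier step, a 5.0-fold higher number from compound 1 to compound 2 (0.70 log units; beyond the scatter), lay on a saturated ring carbon, and only this new pair shows that the number also responds to a change on the unsaturated chain, here in the direction of stronger inhibition. The exchange removes a double bond and adds a hydrogen-bond donor, but nothing available explains the shift or tells which of these differences matters.

On these data alone, it remains open whether the lower number belongs to the hydroxymethyl itself or would also appear with an aminomethyl, a carboxylic acid or a longer chain ending in a hydroxy at this place. The compounds shown also leave open whether the same exchange would move the number in the same direction on the core of compound 2, which carries the additional ring hydroxy.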